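This account rests on a few compounds, and the source may have more. Where it says the series, first, only, none or still open, it means among the compounds named here.

The account begins with compound 1 `C=CC(=O)Nc1cc2c(Nc3ccc(F)c(Cl)c3)ncnc2cc1OCc1cn(CCC(=O)NO)nn1`. In a functional assay on SK-BR-3 cells (Homo sapiens) for antiproliferative activity, read by MTT assay, with a stated time of 72 h (a lower number here means a stronger inhibitor, a higher number a weaker inhibitor), compound 1 gives > 50000 nM, which is a limit of the assay and not a number. Compound 1 therefore stands at the edge of what the assay reports, as the entry the limit of > 50000 nM in this assay, at which 1 of the 2 values shown sits, records, so its true position on the numbers shown remains open. Compound 2 `C=CC(=O)Nc1cc2c(Nc3ccc(OCc4cccc(F)c4)c(Cl)c3)ncnc2cc1OCc1cn(CCC(=O)NO)nn1` carries (3-fluorobenzyl)oxy in place of fluoro on an aromatic carbon, and in this assay compound 2 gives 24800 nM. For the measured compounds named here, the step of an at least 2.0-fold lower number from compound 1 to compound 2 (0.30 log units; that floor lies within the scatter) is the only measured step, and it concerns the aromatic substituent, not the saturated chain that carries the hydroxycarbamoyl group.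

Compound 3 `C=CC(=O)Nc1cc2c(Nc3ccc(F)c(Cl)c3)ncnc2cc1OCc1cn(CCCCC(=O)NO)nn1` differs from compound 1 by 2-(hydroxycarbamoyl)ethyl in place of hydroxycarbamoyl on a saturated chain carbon, two bonds along the chain from an aromatic nitrogen. Going by the values given here, no measured step touches this chain, so the data give no direction for the change, and nothing beyond the scatter is expected from it. Compound 3 is therefore expected at about 50000 nM, with a range from 15000 nM to 200000 nM. This estimate means an expected step of a number no higher from compound 1 to compound 3 (the limit leaves the size open), set close to where compound 1 already stands, with a real chance that the assay again reports only a limit.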

Compound 3, half-maximal inhibitory concentration: 20000 nM
Compound 3: middle estimate off by 2.5-fold (0.40 log units), on the high side, within the range that was stated.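

In this assay, the chain that carries the hydroxycarbamoyl group now has a measured step of its own: 2-(hydroxycarbamoyl)ethyl in place of hydroxycarbamoyl, on a saturated chain carbon, two bonds along the chain from an aromatic nitrogen, gives an at least 2.5-fold lower number from compound 1 to compound 3 (0.39 log units; beyond the scatter). The only earlier step concerned the aromatic substituent and its floor lay within the scatter, whereas the floor of this step lies beyond it, so the change at this position is the first among those shown that clearly lowers the number. Its full size stays unknown, and the step can be read only as a floor: the limit of > 50000 nM in this assay, at which 1 of the 3 values shown sits.

On these data alone, whether a still longer chain ending in the same hydroxycarbamoyl group would lower the number further, or whether a carboxylic acid in place of the hydroxycarbamoyl group would preserve the step, stays open. Also open, as far as these compounds go, is how the longer chain and the (3-fluorobenzyl)oxy group would act together, since each change is seen here only on its own, starting from compound 1.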